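The source may report more compounds than this note shows. Statements on the series, on what has been measured and on what is new or still open speak of the compounds shown alone.

Values from an ADME assay on BJ cells (Homo sapiens) for cytotoxicity, with a stated time of 72 h (a lower number here means that less compound is needed, a higher number that more compound is needed for the effect), follow, and each one is a limit rather than a number:

Compound 1 `CCc1ccc(-c2nc3c(c(C)nn3-c3ccccc3)c(-c3ccccc3O)c2C#N)cc1` gives > 20000 nM as a limit
Compound 2 `C#Cc1ccccc1-c1c(C#N)c(-c2ccc(CC)cc2)nc2c1c(C)nn2-c1ccccc1` gives > 20000 nM as a limit
Compound 3 `CCc1ccc(-c2nc3c(c(-c4ccccc4)nn3-c3ccccc3)c(-c3ccccc3O)c2C#N)cc1` gives > 20000 nM as a limit

Compound 1 therefore has no exact position on the scale, and it shares its place with the other two compounds: the limit of > 20000 nM in this assay, at which 3 of the 3 values shown sit, is all that can be said.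

The next compound to be tested is compound 4 `CCc1ccc(-c2nc3c(c(C)nn3-c3cccc(C)c3)c(-c3ccccc3O)c2C#N)cc1` and it carries one small change from compound 1, methyl in place of hydrogen on an aromatic carbon is the full count of that difference.

Going by the values given here, two measured steps bear on this, although neither is the same change. Among the compounds with values here, the first is a step that the two limits leave unreadable from compound 1 to compound 2 and the second is a step that the two limits leave unreadable from compound 1 to compound 3 and neither has a size that can be read. Within the data shown here, both swaps nevertheless end at the same limit, and that is the only guide available. Given a step that the two limits leave unreadable from compound 1 to compound 3 as the closest precedent, no step beyond the scatter is expected in this assay and no direction can be named. Compound 4 will most likely also be reported only as a limit.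

For compound 4 the estimate is 20000 nM with an expected range from 10000 nM to 40000 nM in this measurement. The estimated change is a number no higher from compound 1 to compound 4 (the limit leaves the size open) and nothing larger is expected.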

Compound 4, half-maximal effective concentration: > 20000 nM
Compound 4 ended at the assay's limit (the forecaster's own chance of this, stated with the estimate: 85%); the middle value lies on the limit itself.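

Going by these compounds alone, compound 1 and compound 4 are both reported only as limits in this assay, so no size can be read for the step between them, and no new step emerges: the limit of > 20000 nM in this assay, at which 4 of the 4 values shown sit.

The compounds shown leave open where the true values of all four lie beyond this limit, and whether changing phenyl to 3-methylphenyl alters the result in this assay at all.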